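The source may hold more compounds than are shown below. What is called first, only, known or untested is meant among the compounds shown, and "the series" means these compounds.

In a functional assay on K562 cells (Homo sapiens) for antiproliferative activity, read by MTT assay, with a stated time of 48 h (a lower number here means a stronger inhibitor of growth, a higher number a weaker inhibitor of growth), compound 1 `COc1ccc(N(C)c2ncnc3[nH]cnc23)cc1` gives > 100000 nM, which is a limit of the assay and not a number. Compound 2 `COc1ccc(Cn2cnc3c(N(C)c4ccc(OC)cc4)ncnc32)cc1` gives > 100000 nM, and this too is only a limit. So compound 2 has no measured potency to build on, and the evidence is thin: the limit of > 100000 nM in this assay, at which 2 of the 2 values shown sit.

Compound 3 `COc1ccc(N(C)c2ncnc3c2ncn3Cc2cc(OC)cc(OC)c2)cc1` changes one part of compound 2: 3,5-dimethoxyphenyl in place of 4-methoxyphenyl on a saturated chain carbon bound to an aromatic nitrogen. In words, 3,5-dimethoxyphenyl stands in place of 4-methoxyphenyl on a saturated chain carbon bound to an aromatic nitrogen.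

Among the measured compounds shown here, only one measured step bears on this change, and it concerns the same chain: a step that the two limits leave unreadable from compound 1 to compound 2. It has no readable size, so it offers neither a magnitude nor a direction to carry over. The safest expectation in this assay is therefore no step beyond the usual scatter, and the expected step is a number no higher from compound 2 to compound 3 (the limit leaves the size open). A reading at the limit again would be the most likely outcome, although a measurable number remains possible. For compound 3 the estimate is 100000 nM, with an expected range of 20000 nM to 150000 nM.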

Compound 3, concentration for 50% growth inhibition: 42000 nM
Beside the measured number, compound 3's estimate is 2.4-fold (0.38 log units) above it, within the range that was stated.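

In this assay, 3,5-dimethoxyphenyl in place of 4-methoxyphenyl on a saturated chain carbon bound to an aromatic nitrogen gives an at least 2.3-fold lower number from compound 2 to compound 3 (0.37 log units; beyond the scatter). This is the first step here that can be read, and it shows that changing the aromatic ring at this position can bring a measurable number out of a series that had shown only limits; the earlier step, with 4-methoxybenzyl in place of hydrogen, cannot be read, since both of its values are limits. The true size of the new step also stays partly hidden, since it starts from a limit, but the number for compound 3 gives later changes at this position a real value to compare against.

Whether a second methoxy group, the placing of the methoxy groups, or both account for the step remains open, as does the outcome with an amine or a carboxylic acid in place of 3,5-dimethoxyphenyl, or with a longer chain in place of the single saturated chain carbon. Any reading of this position also rests on very little so far: the limit of > 100000 nM in this assay, at which 2 of the 3 values shown sit.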